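The compounds below may be only part of what the source reports. "The series", "measured", "known", "first", "only" and "open" are said of these compounds alone.

Of the compounds shown here, two have been measured so far in a functional assay (aorta) with Rattus norvegicus as the target; a higher number here means that more compound is needed for the effect, a lower number that less compound is needed. In this test, compound 1 `COc1ccc(-c2nc(/N=C(\N)N3CCOCC3)sc2-c2ccc(OC)cc2)cc1` gives 66 uM, while compound 2 `CNC(=O)NCc1nc(-c2ccc(OC)cc2)c(-c2ccc(OC)cc2)s1` gives 15 uM, the lower of the two numbers. The next structure, compound 3 `COc1ccc(-c2nc(C(=O)N(C)C)sc2-c2ccc(OC)cc2)cc1`, keeps the two 4-methoxyphenyl groups and differs from compound 2 at one place, on an aromatic carbon of the five-membered aromatic ring: dimethylcarbamoyl in place of ((methylcarbamoyl)amino)methyl on an aromatic carbon. Dimethylcarbamoyl thus replaces ((methylcarbamoyl)amino)methyl.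

Among the measured compounds shown here, only one measured step bears on this change. It is a 4.4-fold lower number from compound 1 to compound 2 (0.64 log units; beyond the scatter), a modest step that also exchanged the group on this aromatic carbon. The dimethylcarbamoyl group appears in neither measured compound, so that step suggests a size but gives no firm direction. With compound 2 at 15 uM, the lower of just two numbers, a modest move towards a higher number in this assay is expected, although the data cannot exclude a result within the scatter. The expected change is a 2.3-fold higher number from compound 2 to compound 3 (0.37 log units; beyond the scatter). The estimated value for compound 3 is 35 uM, with an expected range of 10 uM to 120 uM.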

Compound 3, concentration for half-maximal effect: 3 uM
The estimate for compound 3 lay 12-fold (1.07 log units) above the measured number, and the stated range ends above it.
By their numbers in this assay, from the lowest: compound 3; then compound 2; then compound 1.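

Among the compounds shown here, the step shows for the first time how this aromatic carbon responds to a group with its carbonyl attached directly to the ring: in this assay, dimethylcarbamoyl in place of ((methylcarbamoyl)amino)methyl gives a 5.0-fold lower number from compound 2 to compound 3 (0.70 log units; beyond the scatter). The hydrogen-bond donors of the leaving group are thus not required for a low number in this test, since dimethylcarbamoyl has none and still gives the lowest number of the three. Against the larger ring-bearing group of compound 1, the same replacement gives a 22-fold lower number from compound 1 to compound 3 (1.34 log units; beyond the scatter), which shows that the group on this carbon alone, with both 4-methoxyphenyl groups kept, can move the number substantially, though nothing at hand explains why these groups rank as they do.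

The compounds shown leave open which feature of dimethylcarbamoyl matters, as it differs from ((methylcarbamoyl)amino)methyl in more than one respect and the two differences cannot be separated here. They also leave open how a carboxylic acid, a primary amide or an amide with longer chains on its nitrogen would behave on this same carbon.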